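From hydroxy to chloro on the aryl ketone

The source may report more compounds than this note shows. Statements on the series, on what has been measured and on what is new or still open speak of the compounds shown alone.

Two compounds share one core and differ only in the substituent on the six-membered aromatic ring of carbon only. Compound 1, `COc1ccc(C(=O)/C=C/c2cc3ccccc3[nH]c2=O)cc1`, carries a methyl on the oxygen there; compound 2, `O=C(/C=C/c1cc2ccccc2[nH]c1=O)c1ccc(O)cc1`, carries hydrogen on that oxygen instead. In a functional assay on UACC-257 cells (Homo sapiens) for cytotoxicity, read by sulforhodamine B assay, with a stated time of 24 h (on this read-out lower numbers stand for stronger inhibition of growth and higher numbers for weaker inhibition of growth), compound 1 gives 18000 nM, and compound 2 gives 16000 nM. The step of a 1.1-fold lower number from compound 1 to compound 2 (0.05 log units; within the scatter) shows no real separation: compound 2 has the lower of the two numbers, but by a margin inside the scatter, so neither compound can be called the more active.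

Compound 3, `O=C(/C=C/c1cc2ccccc2[nH]c1=O)c1ccc(Cl)cc1`, has not been measured. It differs from compound 2 by chloro in place of hydroxy on an aromatic carbon. Among the measured compounds shown here, no measured step exchanges hydroxy for chloro; the only measured step, a 1.1-fold lower number from compound 1 to compound 2 (0.05 log units; within the scatter), concerns the same ring and was small. On this thin ground compound 3 is expected to give 14000 nM, a step of a 1.1-fold lower number from compound 2 to compound 3 (0.06 log units; within the scatter), with an expected range of 5000 nM to 40000 nM.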

Compound 3, concentration for total growth inhibition: 46900 nM
The estimate for compound 3 lay 3.4-fold (0.53 log units) below the measured number; the measured number lies above the stated range.
By their numbers in this assay, from the lowest: compounds 2 and 1 (each within the scatter of the next); then compound 3.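

In this assay, the exchange of hydroxy for chloro gives a 2.9-fold higher number from compound 2 to compound 3 (0.47 log units; beyond the scatter), and the exchange of methoxy for chloro gives a 2.6-fold higher number from compound 1 to compound 3 (0.42 log units; beyond the scatter). Both steps are modest, but unlike the earlier change on the oxygen, they lie beyond the scatter, which shows that the number does respond to what stands at this place on the aromatic ring: hydroxy and methoxy cannot be told apart, while chloro goes with weaker inhibition of growth. No measurement available here accounts for this difference.

The compounds shown leave open whether the shift follows from the loss of the oxygen at this place or from the arrival of chlorine, and a fluoro group, a methyl or an amine at the same place would help to separate the two. They also leave open whether a carboxylic acid or a longer alkoxy chain here would stay level with hydroxy and methoxy or move the number as chloro does.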